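Notes on the step from compound 3 to compound 4

The source may hold more compounds than are shown below. What is called first, only, known or untested is meant among the compounds shown, and "the series" means these compounds.

The compounds share one core and differ in a single group on an aromatic carbon. In an ADME assay on cells (Astrocyte, Rattus norvegicus, strain Wistar) for inhibition, read by sulforhodamine B assay, with a stated time of 72 h (on this read-out lower numbers stand for higher toxicity in this test and higher numbers for lower toxicity in this test), compound 1 `O=C(/C=C/c1ccc([N+](=O)[O-])o1)c1ccc(Br)cc1` gives 85400 nM, compound 2 `CSc1ccc(C(=O)/C=C/c2ccc([N+](=O)[O-])o2)cc1` gives 28400 nM and compound 3 `O=C(/C=C/c1ccc([N+](=O)[O-])o1)c1ccc(-n2ccnc2)cc1` gives 45300 nM as its half-maximal cytotoxic concentration. Compound 3 cannot be separated from either neighbour: the step of a 1.9-fold lower number from compound 1 to compound 3 (0.28 log units; within the scatter) and the step of a 1.6-fold higher number from compound 2 to compound 3 (0.20 log units; within the scatter) both stay within the scatter. For the measured compounds named here, only the step of a 3.0-fold lower number from compound 1 to compound 2 (0.48 log units; beyond the scatter) goes beyond it, and that step is modest.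

Compound 4 `O=C(/C=C/c1ccc([N+](=O)[O-])o1)c1ccc(N2CCCC2)cc1` carries pyrrolidin-1-yl in place of 1H-imidazol-1-yl on an aromatic carbon, para to a large group: pyrrolidin-1-yl in place of 1H-imidazol-1-yl on an aromatic carbon. Going by the values given here, no measured compound carries a non-aromatic ring at this place, so the exchange has no direct precedent and the range is kept wide. Among the compounds with values here, the three measured exchanges at this place are the only guide, and the two that involve compound 3 are small. No step beyond the scatter is therefore expected, and no direction is supported. The estimated step is a 1.1-fold lower number from compound 3 to compound 4 (0.03 log units; within the scatter), and it is only an expectation. For compound 4 the expected value is 42000 nM, with an estimated range of 16000 nM to 100000 nM in this assay, pending measurement.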

Compound 4, half-maximal cytotoxic concentration: 65800 nM
The estimate for compound 4 lay 1.6-fold (0.19 log units) below the measured number; the measured number falls inside the stated range.
By their numbers in this assay, from the lowest: compounds 2, 3, 4 and 1 (each within the scatter of the next, the first and the last beyond it).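

The place on the six-membered aromatic ring now holds a non-aromatic ring, and pyrrolidin-1-yl cannot be separated in this assay from either 1H-imidazol-1-yl (a 1.5-fold higher number from compound 3 to compound 4 (0.16 log units; within the scatter)) or bromo (a 1.3-fold lower number from compound 1 to compound 4 (0.11 log units; within the scatter)). Only the exchange of methylsulfanyl for pyrrolidin-1-yl goes beyond the scatter (a 2.3-fold higher number from compound 2 to compound 4 (0.36 log units; beyond the scatter)), and that step is modest, so among these four compounds only compound 2 stands apart from any other, and only from compound 1 and compound 4. Replacing the aromatic ring with two hetero atoms by a non-aromatic ring with one, at the same count of heavy atoms, therefore gives no step beyond the scatter, and no measurement available here bears on the reason for any of these steps.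

As far as these compounds go, it remains open whether an open-chain amine such as dimethylamino, a carboxylic acid or a longer alkyl chain at this place would give a larger step than those seen so far. Also open, from the compounds shown here alone, is whether changes elsewhere on the shared core would move the half-maximal cytotoxic concentration further than exchanges at this place do.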